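A few compounds are considered here, and "the series" means these few. Any claim that something is new, unique, unknown or untested is made for them only; others in the source may bear on it.

Compound 1 `Cc1ccccc1CNc1nn(-c2ccc(F)cc2F)cc1CNCCN1CCN(C)CC1` was tested in an ADME assay on Huh-7 cells (Homo sapiens) for cytotoxicity; on this read-out lower numbers stand for higher toxicity in this test and higher numbers for lower toxicity in this test. For compound 1 the outcome is a limit of the assay rather than a number: compound 1 gives > 20000 nM (the limit of > 20000 nM in this assay, at which 1 of the 2 values shown sits). Compound 2 `CN1CCN(CCNCc2cn(-c3ccc([N+](=O)[O-])cc3)nc2-c2ccc(C(F)(F)F)cc2)CC1` gives 3200 nM in this assay. Compound 3 `Cc1cccc(-c2nn(-c3ccc(F)cc3F)cc2CNCCN2CCN(C)CC2)c1` differs from compound 1 in one place: 3-methylphenyl in place of (2-methylbenzyl)amino on an aromatic carbon. Going by the values given here, no measured pair isolates this change, so the size of the step is uncertain; compound 2, which gives 3200 nM, hints that a number may appear. The step of an at least 1.6-fold lower number from compound 1 to compound 3 (0.22 log units; that floor lies within the scatter) is expected to be small and toward greater toxicity. Compound 3 is estimated at 12000 nM, between 4000 nM and 40000 nM.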

Compound 3, half-maximal cytotoxic concentration: > 20000 nM
Compound 3: no number, only a limit; the forecaster's own chance of this, stated with the estimate: 45%; at least 1.6-fold (0.22 log units) between middle value and limit.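

Compound 1 and compound 3 both give only a limit in this assay, not a number, so no step can be read between them: the limit of > 20000 nM in this assay, at which 2 of the 3 values shown sit.

As far as these compounds go, whether 3-methylphenyl in place of (2-methylbenzyl)amino changes the read-out at all remains open.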